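A benzothiazole in place of a cyanophenyl: what to expect

This account rests on a few compounds, and the source may have more. Where it says the series, first, only, none or still open, it means among the compounds named here.

Of the compounds shown here, three sharing one core have been measured in a functional assay on HepG2 cells (Homo sapiens) for cytotoxicity, read by MTT assay, with a stated time of 72 h; on this read-out lower numbers stand for stronger inhibition and higher numbers for weaker inhibition. Compound 1 `CN(C)CCCOc1c(OCc2ccccc2)cc(O)c2c(=O)cc(-c3ccccc3)oc12` gives 4950 nM and compound 2 `CCN(CC)CCCOc1c(OCc2ccccc2)cc(O)c2c(=O)cc(-c3ccccc3)oc12` gives 3010 nM. Among the compounds with values here, the single step between them, a 1.6-fold lower number from compound 1 to compound 2 (0.22 log units; within the scatter), changes only the amine at the end of the chain and lies within the scatter. Compound 3 `CN1CCN(CCCCOc2c(OCc3ccc(C#N)cc3)cc(O)c3c(=O)cc(-c4ccccc4)oc23)CC1` gives 590 nM, the lowest number of the three, and its gaps to compound 2 and to compound 1 both lie beyond the scatter; compound 3 differs from those two in more than one place, so no single step accounts for that gap.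

Compound 4 `CN1CCN(CCCCOc2c(OCc3nc4ccccc4s3)cc(O)c3c(=O)cc(-c4ccccc4)oc23)CC1` is the untested member. It differs from compound 3 only in 1,3-benzothiazol-2-yl in place of 4-cyanophenyl on a saturated chain carbon bound to an oxygen on an aromatic ring. Within the data shown here, no measured step touches this position: the one step on record, from compound 1 to compound 2, sits on the far end of the amine chain and is itself within the scatter, so it gives no guidance on an aryl swap here. Without such a precedent, the expectation is no step beyond the scatter in this assay, and compound 4 is estimated at 650 nM (range 200 nM to 2200 nM), the step expected from compound 3 to compound 4 being a 1.1-fold higher number from compound 3 to compound 4 (0.04 log units; within the scatter).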

Compound 4, half-maximal inhibitory concentration: 5440 nM
The estimate for compound 4 lay 8.4-fold (0.92 log units) below the measured number; the measured number lies above the stated range.
By their numbers in this assay, from the lowest: compound 3; then compounds 2, 1 and 4 (each within the scatter of the next).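

In this assay the group on a saturated chain carbon bound to an oxygen on an aromatic ring proves to matter: the exchange of 4-cyanophenyl for 1,3-benzothiazol-2-yl gives a 9.2-fold higher number from compound 3 to compound 4 (0.96 log units; beyond the scatter) and so lies beyond the scatter, with everything else in compound 3 unchanged. The earlier compounds offered only a change at the amine end of the chain, a 1.6-fold lower number from compound 1 to compound 2 (0.22 log units; within the scatter), which stayed within the scatter, so this is the only step shown to move the number clearly in this series. Nothing available here bears on why this exchange has this size.

The compounds shown leave open whether the step belongs to the fused five-membered ring with its sulfur or to the loss of the nitrile, and whether a 1,3-benzoxazol-2-yl, with oxygen where the sulfur stands, or a quinolin-2-yl would fall nearer to compound 3 or to compound 4. They also leave open whether the same exchange gives a step of similar size on the shorter dimethylamino and diethylamino chains of compound 1 and compound 2.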